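Benzothiazole amide series: predicting a chlorophenyl analogue

The compounds below may be only part of what the source reports. "The series", "measured", "known", "first", "only" and "open" are said of these compounds alone.

Measured compounds:
Compound 1 `O=C(Cn1cc(-c2ccc([N+](=O)[O-])cc2)nn1)Nc1nccs1` gives 1040 nM.
Compound 2 `Nc1cccc(-c2cn(CC(=O)Nc3nc4ccccc4s3)nn2)c1` gives 1110 nM.
Compound 3 `O=C(Cn1cc(-c2ccc([N+](=O)[O-])cc2)nn1)Nc1nc2ccccc2s1` gives 3280 nM.

All three were tested in a functional assay on BMDM cells (Mus musculus, strain C57BL/6) for inhibition, with a stated time of 2 days; on this read-out higher numbers stand for weaker inhibition and lower numbers for stronger inhibition. Compound 3 has the highest number of the three, sitting a modest distance above compound 2 and compound 1, and both gaps lie beyond the scatter. The unmeasured compound 4 `O=C(Cn1cc(-c2ccccc2Cl)nn1)Nc1nc2ccccc2s1` differs from compound 3 only in the group on the five-membered aromatic ring with 3 nitrogen: 2-chlorophenyl in place of 4-nitrophenyl on an aromatic carbon.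

Of the measured steps, only a 3.0-fold higher number from compound 2 to compound 3 (0.47 log units; beyond the scatter) touches the same aromatic carbon, and it shows that changing the aryl group there moves the number by a modest amount. The other step, a 3.2-fold higher number from compound 1 to compound 3 (0.50 log units; beyond the scatter), concerns the amide-type nitrogen and bears on the present change only indirectly. Among the measured compounds shown here, no measured pair swaps 4-nitrophenyl for 2-chlorophenyl, so the direction remains open.

Compound 4 is therefore expected to land near 2000 nM, with a range from 600 nM to 7000 nM. The estimated step is a 1.6-fold lower number from compound 3 to compound 4 (0.21 log units; within the scatter), which is expected to stay within or just beyond the scatter.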

Compound 4, half-maximal inhibitory concentration: > 30000 nM
Compound 4: only a limit was reported (the forecaster's own chance of this, stated with the estimate: 10%); middle value at least 15-fold (1.17 log units) away from the limit.
By their numbers in this assay, from the lowest: compounds 1 and 2 (each within the scatter of the next); then compound 3. At a limit, above all of these: compound 4.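

In this assay compound 4 returned only a limit of the assay, not a number: the limit of > 30000 nM in this assay, at which 1 of the 4 values shown sits. On this aromatic carbon of the five-membered ring, 2-chlorophenyl in place of 4-nitrophenyl gives an at least 9.1-fold higher number from compound 3 to compound 4 (0.96 log units; beyond the scatter), and 2-chlorophenyl in place of 3-aminophenyl gives an at least 27-fold higher number from compound 2 to compound 4 (1.43 log units; beyond the scatter). Among the compounds shown here, the aryl group at this position can therefore weaken inhibition by more than the only earlier change there showed, which was a 3.0-fold higher number from compound 2 to compound 3 (0.47 log units; beyond the scatter).

The compounds shown leave open whether this loss follows from the chlorine itself or from where it sits on the phenyl ring, a question that plain phenyl or 4-chlorophenyl on the same carbon would address. Also open, going by these compounds, is whether 2-chlorophenyl has the same effect with 1,3-thiazol-2-yl in place of 1,3-benzothiazol-2-yl on the amide-type nitrogen.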